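Working notes: from compound 2 to compound 4

This account rests on a few compounds, and the source may have more. Where it says the series, first, only, none or still open, it means among the compounds named here.

In a functional assay on HeLa cells (Homo sapiens) for antiproliferative activity, read by MTT assay, with a stated time of 72 h (on this read-out lower numbers stand for stronger inhibition and higher numbers for weaker inhibition), compound 1 `C=CC(=O)Nc1cccc(Oc2nc(Nc3ccc(OC)cc3)nc3c2CSCC3)c1` gives 20900 nM while compound 2 `COc1ccc(Nc2nc3c(c(Oc4cccc(NC(=O)C=C(C)C)c4)n2)CSCC3)cc1` gives 19100 nM and compound 3 `COc1ccc(Nc2nc3c(c(Oc4cccc(NC(=O)/C=C/C(C)C)c4)n2)CSCC3)cc1` gives 22900 nM on the shared core. Compound 2 stands level with the other two: the series shows a 1.1-fold lower number from compound 1 to compound 2 (0.04 log units; within the scatter) and a 1.2-fold higher number from compound 2 to compound 3 (0.08 log units; within the scatter) as well as a 1.1-fold higher number from compound 1 to compound 3 (0.04 log units; within the scatter) and none of these separates the compounds.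

Compound 4 `COc1ccc(Nc2nc3c(c(Oc4cccc(NC(=O)C=C(C)C)c4)n2)CSCC3)cn1` keeps the amide side of compound 2 and carries a different change: 6-methoxypyridin-3-yl in place of 4-methoxyphenyl on a nitrogen on an aromatic ring with 6-methoxypyridin-3-yl in place of 4-methoxyphenyl on a nitrogen on an aromatic ring. For the measured compounds named here, none of the measured steps touches that part of the molecule. Going by the values given here, all three alter only the group on a carbonyl carbon, so they bear on the change indirectly at best, and no measured pair tests it. Among the compounds with values here, they show only that the three compounds sit together, and no direction can be drawn from them. The starting point is therefore compound 2 at 19100 nM with no step beyond the scatter expected, though with a wide margin.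

The estimated change is a 1.0-fold higher number from compound 2 to compound 4 (0.02 log units; within the scatter) and it is expected to stay within the scatter. For compound 4 the expected value is 20000 nM with an estimated range from 9000 nM to 45000 nM in this assay as the read-out.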

Compound 4, half-maximal inhibitory concentration: 29200 nM
For compound 4 the middle estimate is 1.5-fold (0.16 log units) below the measured one, and the stated range covers the measured number.
By their numbers in this assay, from the lowest: compounds 2, 1, 3 and 4 (each within the scatter of the next).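

For the compounds shown here, the first measured pair at this position, 6-methoxypyridin-3-yl in place of 4-methoxyphenyl on a nitrogen on an aromatic ring, gives a 1.5-fold higher number from compound 2 to compound 4 (0.18 log units; within the scatter) in this assay, so this single change does not separate the two compounds. Exchanging the carbon-only aromatic ring for one with a hetero atom, with the amide side held constant, therefore leaves the read-out within the scatter, as the changes to the group on the carbonyl carbon did. No supporting data are available that bear on this step or could account for its size.

A single pair cannot show whether the same exchange would also stay within the scatter with the vinyl or 3-methylbut-1-en-1-yl group on the carbonyl carbon. Going by these compounds, it also remains open whether a more different group on this nitrogen, such as a 4-(dimethylamino)phenyl ring, a 4-carboxyphenyl ring or a longer alkoxy chain in place of methoxy, would move the number beyond the scatter.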